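The source may report more compounds than this note shows. Statements on the series, on what has been measured and on what is new or still open speak of the compounds shown alone.

Four compounds built on the same core are compared in a functional assay on KB cells (Homo sapiens) for antiproliferative activity, read by MTT assay, with a stated time of 72 h (on this read-out higher numbers stand for weaker inhibition and lower numbers for stronger inhibition), a test in which a cancer cell line is exposed to each compound and its growth is followed.

Compound 1 `COc1ccc(-c2sc(C(=O)O)cc2-c2cc(OC)c(OC)c(OC)c2)cc1OCc1ccccc1` carries a benzyl ether and a carboxy group on the core. In this assay compound 1 reaches only the limit of > 100000 nM, so no number is known for it. Compound 2 `COc1ccc(-c2sc(C(=O)O)cc2-c2cc(OC)c(OC)c(OC)c2)cc1O` keeps the carboxy group but has a free hydroxy in place of the benzyl ether; in this assay compound 2 gives 11200 nM. The change from compound 1 to compound 2 is hydrogen in place of benzyl on an oxygen on an aromatic ring, and it brings an at least 8.9-fold lower number from compound 1 to compound 2 (0.95 log units; beyond the scatter).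

Compound 3 `COc1ccc(-c2sccc2-c2cc(OC)c(OC)c(OC)c2)cc1OCc1ccccc1` keeps the benzyl ether of compound 1 but lacks the carboxy group; the difference is hydrogen in place of carboxy on an aromatic carbon. In this assay compound 3 also stands at the limit of > 100000 nM, which is a limit and not a number. Because both values sit at the limit of > 100000 nM in this assay, at which 2 of the 3 values shown sit, the step that the two limits leave unreadable from compound 1 to compound 3 cannot be read.

Compound 4 `COc1ccc(-c2sccc2-c2cc(OC)c(OC)c(OC)c2)cc1O` has not yet been measured. It differs from compound 3 by hydrogen in place of benzyl on an oxygen on an aromatic ring, the same kind of change as from compound 1 to compound 2, made on the same place. For the measured compounds named here, since the starting point of compound 3 is a limit, the direction seen from compound 1 to compound 2 is the only guide. On that basis the expected step is an at least 33-fold lower number from compound 3 to compound 4 (1.52 log units; beyond the scatter). Compound 4 is therefore estimated at 3000 nM, between 100 nM and 80000 nM.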

Compound 4, half-maximal inhibitory concentration: 6270 nM
Compound 4: middle estimate off by 2.1-fold (0.32 log units), on the low side, within the range that was stated.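

In this assay, replacing benzyl with hydrogen on the oxygen, so that benzyloxy becomes hydroxy, brings an at least 15-fold lower number from compound 3 to compound 4 (1.20 log units; beyond the scatter), and the change therefore points the same way on the core with the carboxy group and on the core without it, at least in these two pairs. Setting the two steps side by side gives this reading: the same change on two cores in this assay, an at least 8.9-fold lower number (0.95 log units; beyond the scatter) from compound 1 to compound 2 and an at least 15-fold lower number (1.20 log units; beyond the scatter) from compound 3 to compound 4; the limit leaves it open whether they differ

So the direction carries over, but nothing shows that the size does, and two pairs cannot establish a rule for the series; the carboxy group itself makes no clear difference among the compounds with a free hydroxy, with a 1.8-fold lower number from compound 2 to compound 4 (0.25 log units; within the scatter).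

Compound 1 and compound 3 both stand at a limit, so the step between them cannot be read, and the effect of the carboxy group on the benzyl ether core stays unknown: the limit of > 100000 nM in this assay, at which 2 of the 4 values shown sit.

Going by these compounds, it also remains open how other groups would behave on that oxygen, such as an ethyl group or a longer chain ending in an amine, and whether an amide in place of the carboxy group would give a different result.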